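Acetyl in place of hydrogen, second instance in the series

The source may report more compounds than this note shows. Statements on the series, on what has been measured and on what is new or still open speak of the compounds shown alone.

Compound 2 `C=C1CC[C@@H]2[C@](C)(CO)[C@H](OC(C)=O)CC[C@@]2(C)[C@@H]1C/C=C1/C(=O)OC[C@H]1O` gives 58.1 uM in a functional assay on ASK cells (Rattus norvegicus) for cytotoxicity, read by sulforhodamine B assay; on this read-out lower numbers stand for an effect already at smaller amounts and higher numbers for an effect only at larger amounts of compound. Compound 3 `C=C1CC[C@@H]2[C@](C)(CO)[C@H](OC(C)=O)CC[C@@]2(C)[C@@H]1C/C=C1/C(=O)OC[C@H]1OC(C)=O` differs from it by acetyl in place of hydrogen on an oxygen on a saturated carbon and gives 11.5 uM in this assay, the step being a 5.1-fold lower number from compound 2 to compound 3 (0.70 log units; beyond the scatter). Compound 1 `C=C1CC[C@@H]2[C@](C)(CO[Si](c3ccccc3)(c3ccccc3)C(C)(C)C)[C@H](OC(C)=O)CC[C@@]2(C)[C@@H]1C/C=C1/C(=O)OC[C@H]1O` gives 10.5 uM in this assay; the difference between the core of compound 1 and the core of compound 2 is not broken down here, and the values of compound 1 and compound 3 lie within the scatter of each other.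

Compound 4 `C=C1CC[C@@H]2[C@](C)(CO[Si](c3ccccc3)(c3ccccc3)C(C)(C)C)[C@H](OC(C)=O)CC[C@@]2(C)[C@@H]1C/C=C1/C(=O)OC[C@H]1OC(C)=O` differs from compound 1 by acetyl in place of hydrogen on an oxygen on a saturated carbon, the same change at the same place as between compound 2 and compound 3. Beside a 5.1-fold lower number from compound 2 to compound 3 (0.70 log units; beyond the scatter), the expected step is a 3.5-fold lower number from compound 1 to compound 4 (0.54 log units; beyond the scatter), resting on that one measured pair, with a wide range as only one pair shows the change. Compound 4 is expected to give 3 uM in this assay, within 1.2 uM to 8 uM.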

Compound 4, concentration for half-maximal effect: 32.8 uM
For compound 4 the middle estimate is 11-fold (1.04 log units) below the measured one; the whole stated range lies below it.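

In this assay, acetyl in place of hydrogen gives a 3.1-fold higher number from compound 1 to compound 4 (0.49 log units; beyond the scatter), so the change does not carry over from the core of compound 2 to the core of compound 1 and its direction reverses: the same change on two cores in this assay, a 5.1-fold lower number (0.70 log units; beyond the scatter) from compound 2 to compound 3 and a 3.1-fold higher number (0.49 log units; beyond the scatter) from compound 1 to compound 4, 16-fold (1.20 log units) apart, beyond the scatter of two such steps

For this series, a step measured on one core is therefore no safe guide to the same step on the other. Going by these compounds alone, with only two pairs, this does not show which part of the cores goes with the reversal, nor does it give a rule for any further core.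

On these data alone, whether propionyl or benzoyl in place of acetyl would follow the same split between the two cores remains open. Also open, as far as these compounds go, is how a smaller silyl group, such as trimethylsilyl, would behave on the core of compound 1.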